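A few compounds are considered here, and "the series" means these few. Any claim that something is new, unique, unknown or untested is made for them only; others in the source may bear on it.

Of the compounds shown here, three have been measured so far. Compound 1 `C[Se]/C(=N\C(=O)c1cccs1)NC(=O)c1cccs1` was run in an ADME assay on MCF-10A cells (Homo sapiens) for cytotoxicity, read by MTT assay, with a stated time of 72 h (a higher number here means a weaker inhibitor of growth, a lower number a stronger inhibitor of growth), where compound 1 gives 41100 nM. Compound 2 `C[Se]/C(=N\C(=O)c1ccno1)NC(=O)c1ccno1` gives 15400 nM in this assay, and compound 3 `O=C(/N=C(/NC(=O)c1ccco1)[Se]Cc1ccccc1)c1ccco1` gives 58000 nM. Of these three numbers, compound 1 stands second highest: its nearest neighbour is compound 3, whose number is within the usual scatter of that of compound 1, while the furthest is compound 2, whose lower number lies beyond the scatter. No two of these compounds differ in only one place, so no single step between measured compounds can be read off.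

Compound 4 `CS/C(=N\C(=O)c1cccs1)NC(=O)c1cccs1` has not yet been measured. It differs from compound 1 in one place: a group of 2 heavy atoms (1 carbon, 1 sulfur; no ring) in place of a group of 2 heavy atoms (1 carbon, 1 selenium; no ring), on a carbon with a double bond to nitrogen. Among the measured compounds shown here, with no measured step of this kind available, the step of a 1.3-fold higher number from compound 1 to compound 4 (0.13 log units; within the scatter) is the expected size of the change, and it is not expected to go beyond the scatter in either direction. Compound 4 is therefore expected to give about 55000 nM in this assay, within a range from 20000 nM to 150000 nM.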

Compound 4, concentration for total growth inhibition: 55100 nM
For compound 4 the middle estimate is 1.0-fold (0.00 log units) below the measured one, and the stated range covers the measured number.
By their numbers in this assay, from the lowest: compound 2; then compounds 1, 4 and 3 (each within the scatter of the next).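

In this assay, replacing the selenium-bearing group with methylsulfanyl, on a carbon with a double bond to nitrogen whose other neighbours are two amide-type nitrogens, gives a 1.3-fold higher number from compound 1 to compound 4 (0.13 log units; within the scatter). Among the compounds shown here, this is the first direct reading at this position, and it shows that, on the core of compound 1, the exchange of selenium for sulfur makes no difference that can be told from the scatter. No measurement of any property of these two groups is available to account for how close the numbers lie.

This single pair cannot say whether the same exchange would give so small a step on the cores of compound 2 and compound 3. Going by these compounds, how an amine or a methoxy group would read in this place also stays open.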